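The source may hold more compounds than are shown below. What is called first, only, known or untested is meant among the compounds shown, and "the series" means these compounds.

Compound 1 `C(#Cc1nc(-c2ccccc2)nc2c1ncn2Cc1ccccc1)c1ccccc1` and compound 2 `Nc1nc(/C=C/c2ccccc2)c2ncn(Cc3ccccc3)c2n1` share a fused two-ring core carrying a benzyl group, and both have been tested in a functional assay on K562 cells (Homo sapiens) for inhibition, read by thymidine incorporation, with a stated time of 48 h, tested at 10 ug/mL; on this read-out lower numbers stand for less inhibition and higher numbers for more inhibition at the one concentration tested (going by the name of the read-out). In this assay compound 1 gives 100%, and compound 2 gives 91%. These two numbers lie within the usual scatter of each other, so on this read-out nothing separates compound 2 from compound 1; compound 2 simply sits at the same high level of inhibition as its one companion.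

Compound 3 `C(=C/c1nc(-c2ccccc2)nc2c1ncn2Cc1ccccc1)\c1ccccc1` has not been measured yet. It differs from compound 2 in one place: phenyl in place of amino on an aromatic carbon. Compound 3 thus carries the same phenyl group that compound 1 already bears on the core, while keeping the 2-phenylethenyl group of compound 2.

Since compound 1 gives 100% and compound 2 gives 91%, no step beyond the scatter is expected, and the change a number 4 percentage points higher from compound 2 to compound 3 (within the scatter) is estimated to stay within it. Compound 3 is therefore expected to give about 95% in this assay, with a range from 80% to 100%.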

Compound 3, a percentage reported as inhibition, at one concentration (the size of the read-out at that concentration, not a potency): 34%
Compound 3: the middle estimate sits 61 percentage points above what was measured, outside the stated range (below it).
By their numbers in this assay, from the lowest: compound 3; then compounds 2 and 1 (each within the scatter of the next).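

In this assay, phenyl in place of amino on the aromatic carbon between two ring nitrogen atoms goes with a number 57 percentage points lower from compound 2 to compound 3 (beyond the scatter), so with the 2-phenylethenyl group on the shared core, this position is sensitive to what it carries. Replacing 2-phenylethynyl with 2-phenylethenyl on an aromatic carbon, with the phenyl group kept in place, goes with a number 66 percentage points lower from compound 1 to compound 3 (beyond the scatter), so the phenyl group alone does not set the level of inhibition and the change in this second group matters as well. No measurement at hand explains either drop.

The compounds shown leave open whether inhibition falls only with phenyl at this position or also with a methyl group, a methoxy group or a dimethylamino group there, and whether a 2-phenylethyl chain in place of 2-phenylethenyl would behave like either of the two groups seen so far. On these data alone, each number also comes from a single concentration, so how far these compounds differ in potency remains open.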